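The compounds below may be only part of what the source reports. "The series", "measured", "known", "first", "only" and "open" are said of these compounds alone.

Of the compounds shown here, two have numbers so far in a functional assay on HL-60 cells (Homo sapiens) for cytotoxicity, read by MTT assay, with a stated time of 46 h; a lower number here means a stronger inhibitor, a higher number a weaker inhibitor. Compound 1 (`O=C1/C(=C/c2ccncc2)C(c2ccccc2)Oc2ccccc21`) gives 900 nM, while compound 2 (`O=C1/C(=C\c2ccccc2)C(c2ccccc2)Oc2ccccc21`) gives 27300 nM. That makes compound 2 the higher of the two numbers and the weaker inhibitor, with a gap beyond the scatter. The next compound, compound 3 (`O=C1/C(=C/c2ccccc2)C(c2ccccc2)Oc2ccccc21`), has the same atoms and bonds as compound 2: the two compounds have the same atoms and bonds; at least one stereo element is drawn with a configuration in one of them and without one in the other: 1 of 2 stereo elements differ; a double bond is drawn Z in compound 2 and E in compound 3. A double bond is drawn Z in compound 2 and E in compound 3. Going by the values given here, no measured pair yet shows what such a change does in this assay, so any forecast is tentative. Compound 2 at 27300 nM has only a lower neighbour, compound 1 at 900 nM, so a downward step beyond the scatter is expected. The estimated change is a 9.1-fold lower number from compound 2 to compound 3 (0.96 log units; beyond the scatter). Compound 3 is expected at about 3000 nM, within a range of 600 nM to 15000 nM.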

Compound 3, half-maximal inhibitory concentration: 33300 nM
The estimate for compound 3 lay 11-fold (1.05 log units) below the measured number, outside the stated range (above it).
By their numbers in this assay, from the lowest: compound 1; then compounds 2 and 3 (each within the scatter of the next).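

In this assay, changing the double bond from Z to E gives a 1.2-fold higher number from compound 2 to compound 3 (0.09 log units; within the scatter), so with a phenyl group on the chain, the drawn geometry of this bond does not separate the two compounds. Phenyl in place of pyridin-4-yl on the double-bonded chain carbon gives a 37-fold higher number from compound 1 to compound 3 (1.57 log units; beyond the scatter), so among these compounds, the group at this position moves the number far more than the double-bond drawing does. The double-bond comparison carries one caution: the fact that one of compounds 2 and 3 is drawn with a defined configuration and the other without, at the place where they differ

On these data alone, it remains open whether pyridin-4-yl would keep its low number with the double bond drawn the other way. Also open, as far as these compounds go, is how a pyridin-3-yl group, or a phenyl carrying an amine or a carboxylic acid, would behave at this position.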